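Triazole ethers: methylphenyl to nitrophenyl at the benzylic carbon

The source may hold more compounds than are shown below. What is called first, only, known or untested is meant among the compounds shown, and "the series" means these compounds.

Measured so far in a functional assay on SW480 cells (Homo sapiens) for cytotoxicity, read by MTT assay, with a stated time of 48 h; on this read-out lower numbers stand for stronger inhibition and higher numbers for weaker inhibition:
compound 1 `Cc1cccc(Cn2cc(COc3ccc4c(=O)ccoc4c3)nn2)c1`: 11700 nM
compound 2 `Cc1ccc(Cn2cc(COc3ccc4c(=O)ccoc4c3)nn2)cc1`: 10400 nM
compound 3 `Cc1ccccc1Cn1cc(COc2ccc3c(=O)ccoc3c2)nn1`: > 100000 nM; this is a limit of the assay, not a number
compound 4 `O=c1ccoc2cc(OCc3cn(Cc4cccc([N+](=O)[O-])c4)nn3)ccc12`: not yet measured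

Compound 3 stands at the weak end of the three: its value in this assay is only a limit, at the limit of > 100000 nM in this assay, at which 1 of the 3 values shown sits. Compounds 1 and 2 differ by a 1.1-fold lower number from compound 1 to compound 2 (0.05 log units; within the scatter), while moving the methyl to the position of compound 3 gave an at least 8.5-fold higher number from compound 1 to compound 3 (0.93 log units; beyond the scatter) and an at least 9.6-fold higher number from compound 2 to compound 3 (0.98 log units; beyond the scatter). The 2-methylphenyl thus costs activity relative to either 3-methylphenyl or 4-methylphenyl.

The change to compound 4 is 3-nitrophenyl in place of 2-methylphenyl on a saturated chain carbon bound to an aromatic nitrogen. Two things move at once: the substituent returns to the position held in compound 1, and methyl becomes nitro. Going by the values given here, the positional part is covered by the step from compound 1 to compound 3 run backwards; the methyl-to-nitro part has no measured counterpart here. The expectation in this assay is therefore a drop in the number, at least of the size seen between compounds 1 and 3, but it rests on a limit and cannot be sharper than that. Compound 4 is estimated at 13000 nM, range 4000 nM to 60000 nM, which means an expected step of an at least 7.6-fold lower number from compound 3 to compound 4 (0.88 log units; beyond the scatter).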

Compound 4, half-maximal inhibitory concentration: > 100000 nM
Compound 4 was reported as a limit (the forecaster's own chance of this, stated with the estimate: 15%); middle value at least 7.6-fold (0.88 log units) from the limit.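

In this assay compound 4 gives > 100000 nM, a limit of the assay and not a number. Going by these compounds alone, on the benzylic phenyl ring, nitro in place of methyl on an aromatic carbon gives an at least 8.5-fold higher number from compound 1 to compound 4 (0.93 log units; beyond the scatter), and 3-nitrophenyl in place of 4-methylphenyl gives an at least 9.6-fold higher number from compound 2 to compound 4 (0.98 log units; beyond the scatter), so in this small set the 2-methylphenyl of compound 3 is no longer the only change that costs activity, and a substituent at the place held in compound 1 does not by itself keep activity. The step between compound 3 and compound 4 cannot be read, and the two compounds now share the weak end of the series: the limit of > 100000 nM in this assay, at which 2 of the 4 values shown sit.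

Going by these compounds, how far compound 3 and compound 4 lie beyond that limit remains open, so the two cannot be ordered against each other. Also open, on these data alone, is whether the loss is particular to nitro, or whether an amine or a carboxylic acid at the same place on the ring would behave in the same way, and whether 4-nitrophenyl would follow 3-nitrophenyl or 4-methylphenyl.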